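The source may report more compounds than this note shows. Statements on the series, on what has been measured and on what is new or still open speak of the compounds shown alone.

Compound 3 `Cc1c(OCCCCOc2cccc(C(=O)O)c2)ccc(C(=O)CC2CCCC2)c1O` gives in an assay on HEK293 cells for positive allosteric modulation of metabotropic glutamate receptor 3 (Rattus norvegicus), read by thallium flux, with a stated time of 2.5 min (a higher number here means that more compound is needed for the effect, a lower number that less compound is needed), a value of 3400 nM, the only single number among the three entries shown. Compound 1 `Cc1c(OCCCCOc2ccc(C(=O)O)cc2)ccc(C(=O)CC2CCCC2)c1O` reaches only the limit of this assay, > 10000 nM. For compound 2 `Cc1c(OCCCCOc2ccccc2C(=O)O)ccc(C(=O)CC2CCCC2)c1O` this assay shows "not determined" (no result reported). Compound 4 `Cc1cc(OCCCCOc2ccc(C(=O)CC3CCCC3)c(O)c2C)ccc1C(=O)O` has not yet been measured; it differs from compound 3 by 4-carboxy-3-methylphenyl in place of 3-carboxyphenyl on an oxygen on a saturated carbon. For the measured compounds named here, one measured step bears on this change: an at least 2.9-fold lower number from compound 1 to compound 3 (0.46 log units; beyond the scatter), with compound 1 sitting at the limit of > 10000 nM in this assay, at which 1 of the 3 values shown sits. Compound 4 carries the carboxy group as in the 4-carboxyphenyl of compound 1, now with an added methyl, so a step back toward compound 1 is expected, at least modest, and a limit again seems possible. Compound 4 is therefore estimated at 8000 nM, with a range from 2500 nM to 30000 nM, an expected step of a 2.4-fold higher number from compound 3 to compound 4 (0.37 log units; beyond the scatter).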

Compound 4, half-maximal effective concentration: > 10000 nM
Compound 4 ended at the assay's limit; the forecaster's own chance of this, stated with the estimate: 55%; at least 1.2-fold (0.09 log units) between middle value and limit.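

In this assay, 4-carboxy-3-methylphenyl in place of 3-carboxyphenyl gives an at least 2.9-fold higher number from compound 3 to compound 4 (0.46 log units; beyond the scatter). From the compounds shown here alone, compound 4 is therefore a limit of the assay and not a number, like compound 1: the limit of > 10000 nM in this assay, at which 2 of the 4 values shown sit. The step between those two cannot be read, so what the added methyl does on its own remains unknown.

Still open, going by these compounds, is whether a methyl added to the 3-carboxyphenyl group would keep a measurable number. On these data alone, it is also open whether an amide or a tetrazole in place of the carboxylic acid would do so.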